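The compounds below may be only part of what the source reports. "The series", "measured", "known", "first", "only" and "open" are said of these compounds alone.

Among the compounds with values here, compound 2 `C=Cc1cccc(C(=O)NCN2CCC(c3cccc[n+]3[O-])CC2)c1` gives 63% in a functional assay on HEK293 cells for agonist activity at D(4) dopamine receptor (Homo sapiens), read by FLIPR (a lower number here means a smaller maximal response, a higher number a larger maximal response), and holds the lowest of the two numbers measured so far; the nearest is compound 1 `O=C(NCN1CCC(c2cccc[n+]2[O-])CC1)c1ccc(F)c(Cl)c1`, which gives 67%, a gap that lies within the scatter. Within the data shown here, the one step available, a number 4 percentage points lower from compound 1 to compound 2 (within the scatter), exchanges the aryl group on the carbonyl carbon and stays within the scatter. Compound 3 `Cc1cc(C)cc(C(=O)NCN2CCC(c3cccc[n+]3[O-])CC2)c1` differs from compound 2 by 3,5-dimethylphenyl in place of 3-vinylphenyl on a carbonyl carbon. Among the measured compounds shown here, only the step of a number 4 percentage points lower from compound 1 to compound 2 (within the scatter) bears on this change, as it too replaces one aryl group by another on the same carbonyl carbon, and it gave no movement beyond the scatter; no second step exists to weigh against it. Compound 3 is therefore expected to show no step beyond the scatter, a number 1 percentage points higher from compound 2 to compound 3 (within the scatter). The estimate for compound 3 is 64%, with a range from 50% to 78%.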

Compound 3, largest response reached (reported as efficacy), in percent of the reference or control that the assay uses: 56%
Compound 3: the middle estimate sits 8 percentage points above what was measured; the measured number falls inside the stated range.
By their numbers in this assay, from the lowest: compounds 3, 2 and 1 (each within the scatter of the next, the first and the last beyond it).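

Within the data shown here, on the carbonyl carbon, this assay now gives a first step beyond the scatter, though a modest one: a number 11 percentage points lower from compound 1 to compound 3 (beyond the scatter), with 3,5-dimethylphenyl in place of 3-chloro-4-fluorophenyl. The other new step, a number 7 percentage points lower from compound 2 to compound 3 (within the scatter), with 3,5-dimethylphenyl in place of 3-vinylphenyl, stays within the scatter, so this read-out does not separate these two all-carbon groups of 8 heavy atoms each. Nothing available explains why only the first exchange goes beyond the scatter.

Open, going by these compounds, is whether the response at this position depends on the chlorine, the fluorine or both, which 3-chlorophenyl and 4-fluorophenyl would address. Also open, on these data alone, is how far the aryl ring tolerates other substituents, such as an amine or a carboxylic acid, on the same core.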